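Thiazolidinone amides: swapping the ring nitrogen substituent

The source may report more compounds than this note shows. Statements on the series, on what has been measured and on what is new or still open speak of the compounds shown alone.

Measured so far:
compound 1 `O=C(NCCCCc1ccccc1)c1cccc(C2SCC(=O)N2c2ccccn2)c1`: 19.7 nM
compound 2 `O=C(NCCCCc1ccccc1)c1cc(F)cc(C2SCC(=O)N2c2ccccn2)c1`: 14.2 nM

Both numbers come from a functional assay on HOS-TE85 cells (Homo sapiens) for inhibition, read by CCK-8 assay, with a stated time of 72 h; a higher number here means a weaker inhibitor, a lower number a stronger inhibitor. Within the data shown here, compound 1 has the higher of the two numbers; the only step available, a 1.4-fold lower number from compound 1 to compound 2 (0.14 log units; within the scatter), is within the scatter, so compound 1 and compound 2 cannot be told apart on this assay. That step concerns a fluoro in place of hydrogen on an aromatic carbon of the benzamide ring and leaves the rest of the shared core untouched.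

Compound 3 `O=C(NCCCCc1ccccc1)c1cccc(C2SCC(=O)N2c2ccccc2F)c1` is not yet measured. It differs from compound 1 in a different part of the molecule: 2-fluorophenyl in place of pyridin-2-yl on an amide-type nitrogen in a ring. Among the measured compounds shown here, no measured pair changes the group on the amide-type nitrogen in the ring, so nothing measured bears directly on this step. For the measured compounds named here, the one step in hand, a 1.4-fold lower number from compound 1 to compound 2 (0.14 log units; within the scatter), shows that a small change elsewhere in the core did not move the number beyond the scatter. With no relevant comparison, the expectation for compound 3 is a number close to that of compound 1, in either direction, and a step of a 1.0-fold higher number from compound 1 to compound 3 (0.01 log units; within the scatter) is expected to lie within the scatter. Compound 3 is estimated at 20 nM in this assay, with a range from 8 nM to 50 nM.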

Compound 3, half-maximal inhibitory concentration in the HOS-TE85 assay: 34.1 nM
Compound 3: middle estimate off by 1.7-fold (0.23 log units), on the low side; measured number inside the range.
By their numbers in the HOS-TE85 assay, from the lowest: compounds 2, 1 and 3 (each within the scatter of the next, the first and the last beyond it).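

Among these compounds, this is the first change at the amide-type nitrogen in the ring, and it swaps pyridin-2-yl, with its ring nitrogen, for 2-fluorophenyl, an all-carbon aromatic ring carrying fluorine; in the HOS-TE85 assay the result is a 1.7-fold higher number from compound 1 to compound 3 (0.24 log units; within the scatter), so compound 1 and compound 3 cannot be told apart on this read-out. The same holds for the second property: in a physicochemical assay for solubility, read by turbidimetry, measured as kinetic solubility, at pH 6.8 (a lower number here means a less soluble compound, a higher number a more soluble compound), compound 1 gives 20000 nM and compound 3 gives 20000 nM, so this swap shows no separation there either, and the earlier fluoro step offered no such comparison. Nothing available here offers an explanation for how this position behaves.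

Because 2-fluorophenyl differs from pyridin-2-yl both in the ring nitrogen and in the fluorine, the series leaves open what each contributes alone, and an unsubstituted phenyl group on this nitrogen would separate the two. Also open, from the compounds shown here alone, is whether this position accepts larger departures, such as a saturated cyclohexyl ring, or an aryl ring bearing an amine or a carboxylic acid, which could show whether either read-out moves beyond the scatter.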